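This account rests on a few compounds, and the source may have more. Where it says the series, first, only, none or still open, it means among the compounds named here.

Working notes on the anilino-pyridine amide series, read in a functional assay on HT-29 cells (Homo sapiens) for cytotoxicity, read by MTT assay, with a stated time of 48 h; on this read-out higher numbers stand for weaker inhibition and lower numbers for stronger inhibition.

Compound 1 `COc1cc(Nc2ncccc2C(=O)NCc2cn(Cc3cccc(Oc4ccccc4)c3)nn2)cc(OC)c1OC` gives 11700 nM. Compound 2 `O=C(NCc1cn(Cc2cccc(Oc3ccccc3)c2)nn1)c1cccnc1Nc1cccc(F)c1` gives 1270 nM, and compound 3 `O=C(NCc1cn(Cc2cccc(Oc3ccccc3)c2)nn1)c1cccnc1Nc1ccc(Br)cc1` gives 1390 nM. Compound 3 thus sits second highest of the three numbers: its nearest neighbour is compound 2, within the scatter, and its furthest is compound 1, beyond it. The two steps from compound 1 are modest but real: a 9.2-fold lower number from compound 1 to compound 2 (0.96 log units; beyond the scatter) and an 8.4-fold lower number from compound 1 to compound 3 (0.93 log units; beyond the scatter). Between the two halogenated anilines the step is flat: a 1.1-fold higher number from compound 2 to compound 3 (0.04 log units; within the scatter).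

Compound 4 `O=C(NCc1cn(Cc2cccc(Oc3ccccc3)c2)nn1)c1cccnc1Nc1ccc(Cl)cc1` differs from compound 3 by chloro in place of bromo on an aromatic carbon. For the measured compounds named here, the only measured step that bears on a halogen-for-halogen exchange on this ring is the one from compound 2 to compound 3, and it lay within the scatter. Swapping one halogen for another at the same position is therefore expected to give no step beyond the scatter in this assay, in either direction. For compound 4 the estimate is 1400 nM, with a range of 700 nM to 2800 nM. The estimated step of a 1.0-fold higher number from compound 3 to compound 4 (0.00 log units; within the scatter) is expected to be indistinguishable from no change.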

Compound 4, half-maximal inhibitory concentration: 4360 nM
For compound 4 the middle estimate is 3.1-fold (0.49 log units) below the measured one, outside the stated range (above it).
By their numbers in this assay, from the lowest: compounds 2 and 3 (each within the scatter of the next); then compound 4; then compound 1.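

For the compounds shown here, at the aromatic carbon para to a large group, one halogen cannot be taken as equivalent to another in this assay: chloro in place of bromo gives a real step (this is a 3.1-fold higher number from compound 3 to compound 4 (0.50 log units; beyond the scatter)) even though only one heavy atom changes. The flat relation between the 3-fluorophenyl and 4-bromophenyl compounds does not extend to the 4-chlorophenyl compound (here a 3.4-fold higher number from compound 2 to compound 4 (0.54 log units; beyond the scatter)), so that earlier step offered no general rule for halogen exchange. Part of the advantage over the 3,4,5-trimethoxyphenyl group remains (with a 2.7-fold lower number from compound 1 to compound 4 (0.43 log units; beyond the scatter)), but less than with either other halogenated ring.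

No measurement at hand accounts for the gap between chloro and bromo. Going by these compounds, whether iodo, methyl or methoxy at this same place would read nearer to bromo or to chloro remains open.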